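Enantiomers of a chlorophenyl ethyl carbamate pyrazole series

The compounds below may be only part of what the source reports. "The series", "measured", "known", "first", "only" and "open" are said of these compounds alone.

compound 1 `CC(OC(=O)Nc1c(-c2ccc(F)cc2)cnn1C)c1ccccc1Cl`: > 30000 nM
compound 2 `C[C@@H](OC(=O)Nc1c(-c2ccccc2F)cnn1C)c1ccccc1Cl`: > 30000 nM

In an in vitro functional assay on chem-1 cells for antagonist activity at lysophosphatidic acid receptor 3 (Homo sapiens), read by FLIPR and calcium flux, with stated times of 30 min and 100 s (a lower number here means a stronger inhibitor, a higher number a weaker inhibitor), compound 1 shows > 30000 nM, which is a limit of the assay rather than a number. Compound 2 sits at > 30000 nM in this assay, also a limit. Compound 2 therefore stands only at the limit of > 30000 nM in this assay, at which 2 of the 2 values shown sit, with no measured number of its own. Compound 3 `C[C@H](OC(=O)Nc1c(-c2ccccc2F)cnn1C)c1ccccc1Cl` differs from compound 2 as follows: the two compounds have the same atoms and bonds and differ only in configuration as drawn: 1 of 1 stereo elements differ; a stereocentre at a saturated chain carbon is drawn R in compound 2 and S in compound 3. Among the compounds with values here, no step between measured compounds exists here, so the effect of this change in this assay cannot be read from data; no movement beyond the scatter is expected, and a further limit is the likelier outcome. Compound 3 is expected at 40000 nM, between 8000 nM and 200000 nM. The expected step is a step that the limit leaves unreadable from compound 2 to compound 3.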

Compound 3, half-maximal inhibitory concentration: > 30000 nM
Compound 3: a limit, no number (the forecaster's own chance of this, stated with the estimate: 85%); the middle value lies beyond the limit too.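

The step between compound 2 and compound 3 cannot be read: both values in this assay are limits, not numbers. The compounds shown leave open whether configuration at the stereocentre affects potency at all, and what structure gives a measurable value.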